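This account rests on a few compounds, and the source may have more. Where it says the series, first, only, none or still open, it means among the compounds named here.

Measured so far in a functional assay on HCT-116 cells (Homo sapiens) for cytotoxicity, with a stated time of 3 days; a higher number here means a weaker inhibitor, a lower number a stronger inhibitor:
- compound 1 `C=Cc1nc2ccccc2n1C`: 9500 nM
- compound 2 `Cn1c(I)nc2ccccc21`: 17500 nM

Compound 3 `C#Cc1nc2ccccc2n1C` has not yet been measured.

Only these two numbers are available, and compound 2, at 17500 nM, lies within the scatter of compound 1. The next change is ethynyl in place of iodo on an aromatic carbon. Among the measured compounds shown here, one measured step bears on it: a 1.8-fold higher number from compound 1 to compound 2 (0.27 log units; within the scatter), which exchanges vinyl for iodo on that same aromatic carbon and stays within the scatter. For the measured compounds named here, with only this step as a guide, no change beyond the scatter is expected in this assay, and no direction can be firmly expected. The estimate for compound 3 is 11000 nM, with an expected range of 4000 nM to 27000 nM. This estimate means a 1.6-fold lower number from compound 2 to compound 3 (0.20 log units; within the scatter).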

Compound 3, half-maximal inhibitory concentration: 19400 nM
For compound 3 the middle estimate is 1.8-fold (0.25 log units) below the measured one; low and high end bracket the measured number.
By their numbers in this assay, from the lowest: compounds 1, 2 and 3 (each within the scatter of the next, the first and the last beyond it).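

On the aromatic carbon between two ring nitrogen atoms, this assay does not separate ethynyl from iodo, with a 1.1-fold higher number from compound 2 to compound 3 (0.04 log units; within the scatter). Among the compounds shown here, exchanging vinyl for ethynyl at this same carbon gives the first step beyond the scatter, although it is only a modest one: a 2.0-fold higher number from compound 1 to compound 3 (0.31 log units; beyond the scatter). No independent information on these compounds bears on this difference.

The compounds shown carry only vinyl, iodo and ethynyl at this carbon, so it remains open whether an amine, a carboxylic acid or a longer chain there would give a number far from these three. As far as these compounds go, the methyl group is also the same throughout, and the effect of a hydrogen or an ethyl group in its place on the ring atom that bears it remains unknown.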